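The source may report more compounds than this note shows. Statements on the series, on what has been measured and on what is new or still open speak of the compounds shown alone.

In a functional assay on Bel-7402 cells (Homo sapiens) for cytotoxicity, read by MTT assay, with a stated time of 72 h (on this read-out higher numbers stand for weaker inhibition and lower numbers for stronger inhibition), three compounds have been tested so far, and each of them comes back only as a limit of the measurement rather than as a number. Compound 1 `CC/C=C/[C@H]1C[C@](O)(CC)[C@@H]([C@]2(CC)OC(=O)C[C@@H]2O)[C@@H]1C` gives > 100000 nM, a limit. Compound 2 `CCCCC(C)Cc1cc(CC)c(CC(=O)O)o1` gives > 100000 nM, again a limit. Compound 3 `CCCCC(CC)CC(O)(/C=C(/CC)[C@@H](O)CC(=O)OC)CC` gives > 100000 nM, also a limit. So compound 3 stands exactly where the other two tested compounds stand, with nothing to rank it above or below them, as the limit of > 100000 nM in this assay, at which 3 of the 3 values shown sit, shows.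

Compound 4 `CCCCC(C)CC(O)(/C=C(/CC)[C@@H](O)CC(=O)OC)CC` differs from compound 3 in a single place: hydrogen in place of methyl on a saturated chain carbon, four bonds along the chain from a double-bonded chain carbon and an oxygen on a saturated carbon. Among the compounds with values here, no step between two measured compounds exists to show what such a change does in this assay, so the expectation rests only on where compound 3 sits. Given the limit of > 100000 nM for compound 3, the step from compound 3 to compound 4 is expected to be a step that the limit leaves unreadable from compound 3 to compound 4, meaning no change beyond the usual scatter and most likely another limit. Compound 4 is therefore estimated at 200000 nM, with a range from 80000 nM to 600000 nM.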

Compound 4, half-maximal inhibitory concentration: > 100000 nM
Compound 4: a limit, no number; the forecaster's own chance of this, stated with the estimate: 85%; the middle value does not contradict the limit.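

Within the data shown here, compound 3 and compound 4 each come back only as a limit, so no step between them can be read. The compounds shown leave open what actual number any of them would give in this assay, and so which structural changes matter there: the limit of > 100000 nM in this assay, at which 4 of the 4 values shown sit.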